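The source may hold more compounds than are shown below. What is called first, only, known or untested is meant among the compounds shown, and "the series" means these compounds.

Compound 1 `O=C(COc1ccc2cc(C(O)(C(F)(F)F)C(F)(F)F)c(O)cc2c1)Nc1nc2ccccc2s1`: 10900 nM
Compound 2 `CC(C)c1ccc(NC(=O)COc2ccc3cc(C(O)(C(F)(F)F)C(F)(F)F)c(O)cc3c2)cc1`: 7800 nM

For the measured compounds named here, in an assay on isolated protein for inhibition of receptor-type tyrosine-protein phosphatase C (Homo sapiens), read by spectrophotometry (on this read-out lower numbers stand for stronger inhibition and higher numbers for weaker inhibition), compound 2 gives 7800 nM, the lower of the two numbers measured so far, and compound 1 sits nearby at 10900 nM. Compound 3 `O=C(COc1ccc2cc(C(O)(C(F)(F)F)C(F)(F)F)c(O)cc2c1)Nc1ccc(-c2ccccc2)cc1` differs from compound 2 by phenyl in place of isopropyl on an aromatic carbon. Going by the values given here, the only measured step, a 1.4-fold lower number from compound 1 to compound 2 (0.15 log units; within the scatter), also exchanged the group on the amide-type nitrogen and stayed within the scatter. Among the compounds with values here, that step bears on the present change only loosely, and no measured compound carries a phenyl in this place. Compound 3 is therefore expected to stay close to compound 2, with a 1.1-fold lower number from compound 2 to compound 3 (0.05 log units; within the scatter), and its estimated value is 7000 nM, between 3000 nM and 20000 nM.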

Compound 3, half-maximal inhibitory concentration: 3400 nM
The estimate for compound 3 lay 2.1-fold (0.31 log units) above the measured number, within the range that was stated.
By their numbers in this assay, from the lowest: compound 3; then compounds 2 and 1 (each within the scatter of the next).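

In this assay, for the compounds shown here, phenyl in place of isopropyl on the aromatic carbon gave a 2.3-fold lower number from compound 2 to compound 3 (0.36 log units; beyond the scatter), the first step beyond the scatter, so the number does respond to the group at this position. Set against the 1,3-benzothiazol-2-yl group on the amide-type nitrogen, 4-phenylphenyl gave a 3.2-fold lower number from compound 1 to compound 3 (0.51 log units; beyond the scatter). Nothing available accounts for either step. The compounds shown leave open whether the aromatic ring or the higher heavy-atom count matters here; a cyclohexyl group or a longer chain at this position would separate the two.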